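Adding methoxycarbonyl to compound 2: an expected step

This account rests on a few compounds, and the source may have more. Where it says the series, first, only, none or still open, it means among the compounds named here.

Values in a functional assay on P388 cells (Mus musculus) for cytotoxicity; on this read-out higher numbers stand for weaker inhibition and lower numbers for stronger inhibition:
- compound 1 `COc1ccc(C[C@H]2C(=O)N[C@@H](C)C(=O)N(C)[C@H]3Cc4ccc(cc4)Oc4cc(ccc4OC)C[C@@H](C(=O)N[C@H](C)C(=O)N[C@@H](CS)C(=O)N2C)N(C)C3=O)cc1`: 363 nM
- compound 2 `COc1ccc(C[C@H]2C(=S)N[C@@H](C)C(=O)N(C)[C@H]3Cc4ccc(cc4)Oc4cc(ccc4OC)C[C@@H](C(=O)N[C@H](C)C(=O)N[C@@H](C)C(=O)N2C)N(C)C3=O)cc1`: 0.741 nM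
- compound 3 `COc1ccc(C[C@H]2C(=S)N[C@@H](C)C(=O)N(C)[C@H]3Cc4ccc(cc4)Oc4cc(ccc4O)C[C@@H](C(=O)N[C@H](C)C(=O)N[C@@H](C)C(=O)N2C)N(C)C3=O)cc1`: 1.15 nM

In this assay compound 2 gives 0.741 nM. It cannot be told apart from its nearest neighbour, as a 1.6-fold higher number from compound 2 to compound 3 (0.19 log units; within the scatter) shows, and compound 1 stands far higher than both.

Compound 4 `COC(=O)C[C@@H]1NC(=O)[C@@H](C)NC(=O)[C@@H]2Cc3ccc(OC)c(c3)Oc3ccc(cc3)C[C@@H](C(=O)N2C)N(C)C(=O)[C@H](C)NC(=S)[C@H](Cc2ccc(OC)cc2)N(C)C1=O` has not yet been measured. It differs from compound 2 as follows: methoxycarbonyl in place of hydrogen on a saturated chain carbon bound to a saturated ring carbon. This is methoxycarbonyl in place of hydrogen on a saturated chain carbon bound to a saturated ring carbon, which can also be read as methyl to (methoxycarbonyl)methyl.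

Among the compounds with values here, only one measured step exists, a 1.6-fold higher number from compound 2 to compound 3 (0.19 log units; within the scatter), and it is hydrogen in place of methyl on an oxygen on an aromatic ring. Within the data shown here, that is a different place, so it offers no direct guide, and no measured step touches this carbon. Among the measured compounds shown here, compound 1, at 363 nM, shows only that numbers in this set can lie far above that of compound 2. A higher number beyond the scatter is therefore expected in this assay, with its size poorly defined. The expected change is a 54-fold higher number from compound 2 to compound 4 (1.73 log units; beyond the scatter). For compound 4 the estimate is 40 nM, with an expected range of 4 nM to 300 nM.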

Compound 4, half-maximal inhibitory concentration: 4.79 nM
Estimate against measurement, compound 4: 8.4-fold (0.92 log units) above; measured number inside the range.
By their numbers in this assay, from the lowest: compounds 2 and 3 (each within the scatter of the next); then compound 4; then compound 1.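

In this assay, within the data shown here, the change from methyl to (methoxycarbonyl)methyl gives a 6.5-fold higher number from compound 2 to compound 4 (0.81 log units; beyond the scatter) and supplies the first measured step at this saturated chain carbon bound to a saturated ring carbon. The step lies beyond the scatter but is modest, so this position tolerates methoxycarbonyl, a group of 4 heavy atoms with 2 hydrogen-bond acceptors and no hydrogen-bond donors, with some loss of inhibition: compound 4 still gives 4.79 nM in this read-out. Nothing available explains why this change raises the number.

Among the compounds shown, methoxycarbonyl is the only larger group at this carbon, so it remains open how a carboxylic acid, an amine, a hydroxymethyl group or a longer chain such as ethoxycarbonyl would compare with it. It also remains open whether the step would keep its size in compound 3, which carries hydrogen in place of methyl on an oxygen on an aromatic ring, as the compounds shown give this step only from compound 2.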